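Thiophene attachment point on the pyridine core

The source may hold more compounds than are shown below. What is called first, only, known or untested is meant among the compounds shown, and "the series" means these compounds.

Of the compounds shown here, two have been measured in a functional assay on DU-145 cells (Homo sapiens) for cytotoxicity, in the presence of a further agent that is not named here; a higher number here means a weaker inhibitor, a lower number a stronger inhibitor. Compound 1 `Cc1ccccc1-c1cc(-c2ccc(Cl)o2)cc(-c2ccsc2)n1` gives 24800 nM in this assay. Compound 2 `Clc1ccc(-c2cc(-c3ccc(Cl)o3)cc(-c3ccsc3)n2)cc1` gives 19500 nM in this assay, the lowest of the two numbers, with compound 1 the nearest; the step of a 1.3-fold lower number from compound 1 to compound 2 (0.10 log units; within the scatter) is within the scatter, so the two are indistinguishable on these data.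

Compound 3 `Clc1ccc(-c2cc(-c3ccc(Cl)o3)cc(-c3cccs3)n2)cc1` has not yet been measured. It differs from compound 2 only in thiophen-2-yl in place of thiophen-3-yl on an aromatic carbon. Among the measured compounds shown here, no measured pair touches this change: the single step available, from compound 1 to compound 2, concerns the aryl group on the other side of the core and was itself within the scatter, so it gives no direction for the present change.

With nothing in the series bearing on the move of the thiophene attachment point, the expectation for compound 3 in this assay is a step of no change at the digits printed from compound 2 to compound 3 (within the scatter), that is, no change beyond the scatter. The estimate for compound 3 in this assay is 19500 nM, with a range from 7000 nM to 55000 nM.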

Compound 3, half-maximal inhibitory concentration: 19200 nM
Beside the measured number, compound 3's estimate is 1.0-fold (0.01 log units) above it; low and high end bracket the measured number.
By their numbers in this assay, from the lowest: compounds 3, 2 and 1 (each within the scatter of the next).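

In this assay, moving the thiophene attachment point gives a 1.0-fold lower number from compound 2 to compound 3 (0.01 log units; within the scatter), so thiophen-2-yl and thiophen-3-yl cannot be told apart on the carbon next to the ring nitrogen. Among the compounds shown here, this is the first measured pair to touch that carbon, as the earlier step concerned only the aryl group on the other side of the shared core; the two groups match in heavy atoms, ring type and hydrogen-bond counts, and differ only in how they are joined to the core. For the compounds shown here, no supporting data bear on why the attachment point leaves the number within the scatter, and the pair shows only that this one swap does not separate the two compounds in this cell assay.

Still open, on these data alone, is whether this carbon responds to anything other than a thiophene, for example a non-aromatic amine such as piperidine or a group carrying a carboxylic acid. The 5-chlorofuran-2-yl group is also common to all the compounds shown, so its contribution to the numbers in this assay remains unknown.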